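A few compounds are considered here, and "the series" means these few. Any claim that something is new, unique, unknown or untested is made for them only; others in the source may bear on it.

Compound 1 `Oc1ccc2cc1Oc1ccc(cc1)CCc1ccc(CN3CCCC3)c(O)c1-c1ccc(cc1O)CC2`: 2410 nM
Compound 2 `CCCCN(CCCC)Cc1ccc2c(c1O)-c1ccc(cc1O)CCc1ccc(O)c(c1)Oc1ccc(cc1)CC2`: > 20000 nM (a limit)

Both compounds were read in a functional assay on MCF7 cells (Homo sapiens) for antiproliferative activity, read by MTT assay, with a stated time of 48 h; on this read-out higher numbers stand for weaker inhibition and lower numbers for stronger inhibition. Within the data shown here, compound 1 is the only one of the pair with an actual number, 2410 nM. Compound 2 gives only a limit, > 20000 nM.

Compound 3 `Oc1cc2ccc1-c1c(ccc(CN3CCCC3)c1O)CCc1ccc(cc1)Oc1cc(cc(CN3CCCC3)c1O)CC2` keeps the core of compound 1 and carries (pyrrolidin-1-yl)methyl in place of hydrogen on an aromatic carbon, that is, (pyrrolidin-1-yl)methyl in place of hydrogen on an aromatic carbon, ortho to a hydroxy group. Among the measured compounds shown here, the only measured step is an at least 8.2-fold higher number from compound 1 to compound 2 (0.91 log units; beyond the scatter), with dibutylamino in place of pyrrolidin-1-yl. It rests on (the limit of > 20000 nM in this assay, at which 1 of the 2 values shown sits). For the measured compounds named here, that step exchanges one amine for another and adds no new group, so it bears only loosely on compound 3, and no measured step covers this change. A shift in this assay beyond the scatter is therefore not expected, though a move to a higher number remains possible.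

The expected outcome is a 1.5-fold higher number from compound 1 to compound 3 (0.16 log units; within the scatter).

For compound 3 the estimated value is 3500 nM, with an expected range of 900 nM to 14000 nM.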

Compound 3, half-maximal inhibitory concentration: 430 nM
Compound 3: the middle estimate sits 8.1-fold (0.91 log units) above what was measured; the whole stated range lies above it.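

In this assay, (pyrrolidin-1-yl)methyl in place of hydrogen on this aromatic carbon, ortho to a hydroxy group, gives a 5.6-fold lower number from compound 1 to compound 3 (0.75 log units; beyond the scatter). This position therefore tolerates a further (pyrrolidin-1-yl)methyl group with a gain in antiproliferative activity, whereas the earlier pair varied only the amine on the existing chain and said nothing about this place on the shared core. Nothing in the data shown accounts for the gain.

From the compounds shown here alone, it remains open whether morpholin-4-ylmethyl or dimethylaminomethyl at this position would also lower the number, or whether the effect is specific to the pyrrolidine ring. Also open, going by these compounds, is whether (pyrrolidin-1-yl)methyl at this position would give the same result without the matching group already present in compound 1.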